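The source may hold more compounds than are shown below. What is called first, only, known or untested is meant among the compounds shown, and "the series" means these compounds.

Compound 1 `N#Cc1ccc(F)cc1Cn1c(N2CCC[C@@H](N)C2)nc2c(F)c[nH]c2c1=O`: 0.838 h
Compound 2 `CC(C)S(=O)(=O)c1ccc(-c2c[nH]c3c(=O)n(Cc4cc(F)ccc4C#N)c(N4CCC[C@@H](N)C4)nc23)cc1`: > 3.33 h

Both values come from an ADME assay on microsomes from liver (Rattus norvegicus) for metabolic stability, read by LC-MS, tested at 1 mM; on this read-out lower numbers stand for a shorter-lived compound and higher numbers for a longer-lived compound. Compound 2 gives > 3.33 h, which is a limit of the assay and not a number. Going by these compounds, it therefore stands at the limit of > 3.33 h in this assay, at which 1 of the 2 values shown sits, and its true half-life is unknown.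

Compound 3 `CS(=O)(=O)c1cccc(-c2c[nH]c3c(=O)n(Cc4cc(F)ccc4C#N)c(N4CCC[C@@H](N)C4)nc23)c1` is made from compound 2 by one change: 3-(methylsulfonyl)phenyl in place of 4-(isopropylsulfonyl)phenyl on an aromatic carbon. In words, 3-(methylsulfonyl)phenyl takes the place of 4-(isopropylsulfonyl)phenyl on an aromatic carbon of the five-membered aromatic ring.

For the measured compounds named here, only one measured step bears on this change. At that same carbon, replacing fluoro with 4-(isopropylsulfonyl)phenyl gave an at least 3.9-fold higher number from compound 1 to compound 2 (0.59 log units; beyond the scatter), a step beyond the scatter. Going by the values given here, no measured step swaps one sulfonyl-bearing phenyl for another, so the size of this exchange rests on judgement. Compound 3 still carries a sulfonyl-bearing phenyl, so it is expected to stay closer to compound 2 than to compound 1 with its 0.838 h. No change beyond the scatter is expected in this assay, and the expected step is a step that the limit leaves unreadable from compound 2 to compound 3. For compound 3 the estimated half-life is 3.5 h, with an expected range from 1.5 h to 8 h.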

Compound 3, half-life: 1.65 h
Estimate against measurement, compound 3: 2.1-fold (0.33 log units) above; measured number inside the range.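

In this assay, the exchange of 4-(isopropylsulfonyl)phenyl for 3-(methylsulfonyl)phenyl gives an at least 2.0-fold lower number from compound 2 to compound 3 (0.30 log units; that floor lies within the scatter), so a drop in half-life is possible but this floor alone does not establish one. The true size of this step cannot be read, because compound 2 stands at a limit and not at a number: the limit of > 3.33 h in this assay, at which 1 of the 3 values shown sits. With fluoro on the same aromatic carbon as the reference, the new group gives a 2.0-fold higher number from compound 1 to compound 3 (0.29 log units; within the scatter), whereas the step to compound 2 lay beyond the scatter, so a sulfonyl-bearing phenyl at this carbon does not by itself ensure a clear rise in half-life.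

The exchange alters two things at once, the place of the sulfonyl on the phenyl ring and the group it carries, and these compounds cannot separate the two. 4-(Methylsulfonyl)phenyl or 3-(isopropylsulfonyl)phenyl at this carbon would change only one of them, and a measured number for compound 2 in place of its limit would be needed to fix the size of the step.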